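The compounds below may be only part of what the source reports. "The series", "measured", "known", "first", "only" and "open" are said of these compounds alone.

Compound 1 `CCCCCCc1cn(-c2ccc(O)c(C(=O)NCCC)c2)nn1` is measured in a functional assay on RAW264.7 cells (Mus musculus) for inhibition, read by Griess assay, with a stated time of 20 h (on this read-out lower numbers stand for stronger inhibition and higher numbers for weaker inhibition), where compound 1 gives 19700 nM. Compound 2 `CCCNC(=O)c1cc(-n2cc(-c3cccc(Cl)c3)nn2)ccc1O` differs from it by 3-chlorophenyl in place of hexyl on an aromatic carbon. In this assay compound 2 reaches only a limit, > 20000 nM. That change made an at least 1.0-fold higher number from compound 1 to compound 2 (0.00 log units; that floor lies within the scatter), a floor set because the limit of > 20000 nM in this assay, at which 2 of the 3 values shown sit, is where the value of compound 2 sits. Compound 3 `CCCCCCc1cn(-c2ccc(C(=O)NCCC)c(O)c2)nn1` has the same atoms as compound 1 joined differently; the difference between the two cores is not broken down here. In this assay compound 3 likewise reaches only a limit, > 20000 nM. Compound 4 `CCCNC(=O)c1ccc(-n2cc(-c3cccc(Cl)c3)nn2)cc1O` stands to compound 3 as compound 2 to compound 1, the change being (3-chlorophenyl in place of hexyl on an aromatic carbon), the same change on the same place. Since compound 3 already sits at a limit, compound 4 is expected to show a step that the limit leaves unreadable from compound 3 to compound 4, most likely again reported only as a limit, with an estimated value of 35000 nM.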

Compound 4, half-maximal inhibitory concentration: > 20000 nM
Compound 4: a limit, no number (the forecaster's own chance of this, stated with the estimate: 85%); the middle value lies beyond the limit too.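

Compound 3 and compound 4 both reach only a limit in this assay, so no step between them can be read: the limit of > 20000 nM in this assay, at which 3 of the 4 values shown sit.

The compounds shown leave open how far past that limit compound 2, compound 3 and compound 4 lie, and whether 3-chlorophenyl in place of hexyl changes inhibition on either core.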